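The compounds below may be only part of what the source reports. "The series", "measured", "known", "first", "only" and "open" are said of these compounds alone.

Compound 1 `CC(C)CN(CC(=O)N(CC(C)C)NC(=O)OCc1ccccc1)NC(=O)CBr` serves as the starting point of this series. In a functional assay on B16 cells (Mus musculus) for inhibition (on this read-out lower numbers stand for stronger inhibition and higher numbers for weaker inhibition), compound 1 gives 1300 nM. Compound 2 `CC(C)CN(NC(=O)OCc1ccccc1)C(=O)CN(Cc1ccccc1)NC(=O)CBr` carries the change phenyl in place of isopropyl on a saturated chain carbon bound to an amine nitrogen relative to compound 1, and in this assay compound 2 gives 1400 nM; the step is a 1.1-fold higher number from compound 1 to compound 2 (0.03 log units; within the scatter). Compound 3 `CC(C)CN(CC(=O)N(CC(C)C)NC(=O)OCc1ccccc1)/N=C/c1cccc(B(O)O)c1` differs from compound 1 in its core by a group of 11 heavy atoms (7 carbon, 1 boron, 1 nitrogen, 2 oxygen; one six-membered aromatic ring of carbon only) in place of a group of 5 heavy atoms (2 carbon, 1 nitrogen, 1 oxygen, 1 bromine; no ring), on an amine nitrogen, and in this assay compound 3 gives 53900 nM, which is the step of a 41-fold higher number from compound 1 to compound 3 (1.62 log units; beyond the scatter) and the highest number of the three. Compound 4 `CC(C)CN(NC(=O)OCc1ccccc1)C(=O)CN(Cc1ccccc1)/N=C/c1cccc(B(O)O)c1` is the unmeasured member. Within the data shown here, it relates to compound 3 by phenyl in place of isopropyl on a saturated chain carbon bound to an amine nitrogen, the same change as the one from compound 1 to compound 2, made on the core of compound 3 rather than the core of compound 1. The change left the number essentially unmoved in the earlier pair, so a step of a 1.0-fold higher number from compound 3 to compound 4 (0.01 log units; within the scatter) from compound 3 is expected, resting on the step of a 1.1-fold higher number from compound 1 to compound 2 (0.03 log units; within the scatter). Among the measured compounds shown here, the starting value of that expected step is the one compound 3 gives, 53900 nM. Compound 4 is therefore estimated at 55000 nM in this assay, with a plausible range from 20000 nM to 150000 nM.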

Compound 4, half-maximal inhibitory concentration: 20400 nM
Beside the measured number, compound 4's estimate is 2.7-fold (0.43 log units) above it, and the stated range covers the measured number.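

On the core of compound 3, phenyl in place of isopropyl gave a 2.6-fold lower number from compound 3 to compound 4 (0.42 log units; beyond the scatter) in this assay, so the change did not carry over from the core of compound 1 with its effect unchanged: the same change on two cores in this assay, a 1.1-fold higher number (0.03 log units; within the scatter) from compound 1 to compound 2 and a 2.6-fold lower number (0.42 log units; beyond the scatter) from compound 3 to compound 4, 2.8-fold (0.45 log units) apart, beyond the scatter of two such steps. Seen from the other side, the group of 11 heavy atoms raised the number on both cores, but the rise of a 15-fold higher number from compound 2 to compound 4 (1.16 log units; beyond the scatter) was smaller than the one on the isopropyl-bearing core: the same change on two cores in this assay, a 41-fold higher number (1.62 log units; beyond the scatter) from compound 1 to compound 3 and a 15-fold higher number (1.16 log units; beyond the scatter) from compound 2 to compound 4, 2.8-fold (0.45 log units) apart, beyond the scatter of two such steps. This shows that the effect of the change depended on the core in these four compounds, but with one pair on each core it shows neither why nor whether the same would hold for other pairs in this series.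

The compounds shown leave open how a cyclohexyl group, a longer chain or an amine would behave on a saturated chain carbon bound to an amine nitrogen on either core. They also leave open whether a carboxylic acid in place of the group of 11 heavy atoms would shift the number as that group does.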